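The compounds below may be only part of what the source reports. "The series", "measured", "known", "first", "only" and "open" are said of these compounds alone.

- Compound 1 `Cn1ncc(Cl)c1-c1cc(C(=O)N[C@@H]2CN[C@H](CCn3cncn3)C[C@H]2c2ccc(Cl)c(Cl)c2)oc1Cl`: 60 nM
- Compound 2 `Cn1ncc(Cl)c1-c1cc(C(=O)N[C@@H]2CN[C@H](CC(=O)O)C[C@H]2c2ccc(Cl)c(Cl)c2)oc1Cl`: 640 nM
- Compound 3 `Cn1ncc(Cl)c1-c1cc(C(=O)N[C@@H]2CN[C@H](CCO)C[C@H]2c2ccc(Cl)c(Cl)c2)oc1Cl`: 160 nM

In a functional assay on LNCaP cells (Homo sapiens) for antiproliferative activity (a lower number here means a stronger inhibitor, a higher number a weaker inhibitor), compound 3 stands in the middle of the three, with compound 1 lower and compound 2 higher. Compound 4 `Cn1ncc(Cl)c1-c1cc(C(=O)N[C@@H]2CN[C@H](CC(=O)NC3CCC3)C[C@H]2c2ccc(Cl)c(Cl)c2)oc1Cl` has cyclobutylcarbamoyl in place of hydroxymethyl on a saturated chain carbon bound to a saturated ring carbon. Three measured steps change this same chain: a 2.7-fold higher number from compound 1 to compound 3 (0.43 log units; beyond the scatter), a 4.0-fold lower number from compound 2 to compound 3 (0.60 log units; beyond the scatter) and an 11-fold higher number from compound 1 to compound 2 (1.03 log units; beyond the scatter). The new group ends in a ring, as does the chain of compound 1 at 60 nM, but keeps a carbonyl, as does compound 2 at 640 nM. These precedents pull in opposite directions, so only a small move toward lower numbers is expected, a 1.3-fold lower number from compound 3 to compound 4 (0.12 log units; within the scatter). Compound 4 is estimated at 120 nM, with an expected range of 40 nM to 360 nM.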

Compound 4, half-maximal inhibitory concentration: 80 nM
Compound 4: middle estimate off by 1.5-fold (0.18 log units), on the high side; measured number inside the range.
By their numbers in this assay, from the lowest: compounds 1, 4 and 3 (each within the scatter of the next, the first and the last beyond it); then compound 2.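

In this assay, replacing the hydroxy of the carboxy group with cyclobutylamino gives an 8.0-fold lower number from compound 2 to compound 4 (0.90 log units; beyond the scatter), so on this chain the free carboxy group is not required and its amide performs far better. The amide cannot be told apart from either neighbouring chain, as a 2.0-fold lower number from compound 3 to compound 4 (0.30 log units; within the scatter) and a 1.3-fold higher number from compound 1 to compound 4 (0.12 log units; within the scatter) both lie within the scatter, so this position tolerates the added cyclobutyl ring. Nothing here explains these steps. Still open, as far as these compounds go, is whether the cyclobutyl ring itself matters, or whether an unsubstituted carbamoyl group or an amine on the same chain would match compound 4.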